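Swapping an Ethynyl Arm for a Furan Ring

This account rests on a few compounds, and the source may have more. Where it says the series, first, only, none or still open, it means among the compounds named here.

Compound 1 `CN(C)c1ncnc2c1c(-c1ccoc1)cn2[C@@H]1O[C@H](CO)[C@@H](O)[C@H]1O` gives 12500 nM in a functional assay on HepG2 cells (Homo sapiens) for antiproliferative activity, read by XTT assay, with a stated time of 72 h; on this read-out higher numbers stand for weaker inhibition and lower numbers for stronger inhibition.
Compound 2 `C#Cc1cn([C@@H]2O[C@H](CO)[C@@H](O)[C@H]2O)c2ncnc(N(C)C)c12` gives 1320 nM in this assay.
Compound 3 `C#Cc1cn([C@@H]2O[C@H](CO)[C@@H](O)[C@H]2O)c2nc(N)nc(OC)c12` gives in this assay only a limit of the assay, > 20000 nM.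

Compound 1 and compound 2 share a core and differ in one spot: furan-3-yl in place of ethynyl on an aromatic carbon. That exchange made a 9.5-fold higher number from compound 2 to compound 1 (0.98 log units; beyond the scatter), so the furan-bearing compound is the weaker of the pair. Compound 3 carries a different core; the difference between the two cores is not broken down here. Its value is a limit and not a number, and it sits at the limit of > 20000 nM in this assay, at which 1 of the 3 values shown sits.

Compound 4 `COc1nc(N)nc2c1c(-c1ccoc1)cn2[C@@H]1O[C@H](CO)[C@@H](O)[C@H]1O` is not yet measured. It arises from compound 3 by furan-3-yl in place of ethynyl on an aromatic carbon, the same change seen between compound 2 and compound 1, and at the same place word for word. In this assay compound 4 is therefore expected to give a weaker result again, roughly a step that the limit leaves unreadable from compound 3 to compound 4, resting on the earlier step of a 9.5-fold higher number from compound 2 to compound 1 (0.98 log units; beyond the scatter). Since compound 3 already sits at a limit, compound 4 is expected to fall beyond it as well, most likely again reported as a limit rather than a number. The estimate for compound 4 is 60000 nM, spanning from 20000 nM to 200000 nM.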

Compound 4, half-maximal inhibitory concentration: > 20000 nM
Compound 4 ended at the assay's limit; the forecaster's own chance of this, stated with the estimate: 85%; the middle value lies beyond the limit too.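

In this assay compound 4 gives > 20000 nM, which is a limit of the assay and not a number. Compound 3 also stands at a limit, so no step can be read from compound 3 to compound 4: the limit of > 20000 nM in this assay, at which 2 of the 4 values shown sit.

From the compounds shown here alone, whether furan-3-yl in place of ethynyl weakens the result on the core of compound 3, as it does on the core of compound 2, stays open.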